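From 4-(tert-butyl)benzyl to 3-chlorobenzyl on compound 1

The source may report more compounds than this note shows. Statements on the series, on what has been measured and on what is new or still open speak of the compounds shown alone.

Measured so far in a functional assay on NCI-H460 cells (Homo sapiens) for cytotoxicity, read by MTT assay, with a stated time of 72 h; a lower number here means a stronger inhibitor, a higher number a weaker inhibitor:
compound 1 `CCN(CC)Cc1ccc2nc(NC(=O)N/N=C/c3cn(Cc4ccc(C(C)(C)C)cc4)c4ccccc34)sc2c1` gives 1670 nM
compound 2 `CN(C)Cc1ccc2nc(NC(=O)N/N=C/c3cn(Cc4ccc(C(C)(C)C)cc4)c4ccccc34)sc2c1` gives 810 nM
compound 3 `CN(C)Cc1ccc2nc(NC(=O)N/N=C3\C(=O)Nc4ccc(F)cc43)sc2c1` gives 1550 nM

Compound 1 and compound 3 sit together at the high end of these numbers, within the scatter of each other, while compound 2 lies lower (see a 2.1-fold lower number from compound 1 to compound 2 (0.31 log units; beyond the scatter)).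

The next compound is compound 4 `CCN(CC)Cc1ccc2nc(NC(=O)N/N=C/c3cn(Cc4cccc(Cl)c4)c4ccccc34)sc2c1` and it differs from compound 1 by 3-chlorophenyl in place of 4-(tert-butyl)phenyl on a saturated chain carbon bound to an aromatic nitrogen.

Within the data shown here, no measured step covers this place. Among the measured compounds shown here, the one measured step, dimethylamino in place of diethylamino, is modest and gives only a rough scale for a single substitution: a 2.1-fold lower number from compound 1 to compound 2 (0.31 log units; beyond the scatter). Compound 3 (at 1550 nM) carries neither the leaving nor the entering group, yet its value lies within the scatter of that of compound 1. A change of no more than that modest size is therefore expected in this assay, most likely none beyond the scatter, and the data support no firm direction.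

The expected change is a 1.2-fold lower number from compound 1 to compound 4 (0.08 log units; within the scatter) in this estimate.
Compound 4 is estimated at 1400 nM in this read-out.
The expected range for compound 4 runs from 550 nM to 3500 nM in this estimate.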

Compound 4, half-maximal inhibitory concentration: 220 nM
Compound 4: the middle estimate sits 6.4-fold (0.80 log units) above what was measured, and the stated range ends above it.
By their numbers in this assay, from the lowest: compound 4; then compounds 2, 3 and 1 (each within the scatter of the next, the first and the last beyond it).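

In this assay the group on a saturated chain carbon bound to an aromatic nitrogen proves to be a place where the number responds strongly: 3-chlorophenyl in place of 4-(tert-butyl)phenyl gives a step (a 7.6-fold lower number from compound 1 to compound 4 (0.88 log units; beyond the scatter)) larger than the one seen on the amine side (a 2.1-fold lower number from compound 1 to compound 2 (0.31 log units; beyond the scatter)). The 4-(tert-butyl)phenyl group is therefore not needed for the lower numbers in this series, and the entering 3-chlorophenyl, with the lower heavy-atom count of the two groups, does better on the core of compound 1. No measured evidence here explains why this change lowers the number.

The step swaps both the substituent and its place on the phenyl ring, so the compounds shown cannot separate the contribution of the chlorine from that of removing the tert-butyl group, and an unsubstituted phenyl or a phenyl bearing a methoxy group would help to divide the two. From the compounds shown here alone, it also remains open whether the same change on compound 2, with its dimethylamino group, would give a step of similar size.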